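Chloro for nitro on the aryl ring of compound 3

The compounds below may be only part of what the source reports. "The series", "measured", "known", "first", "only" and "open" are said of these compounds alone.

Measured compounds:
compound 1, `O=C1C[C@H](OCc2cn(-c3ccccc3)nn2)[C@H]2CO[C@@H]1O2` — 10900 nM
compound 2, `C=C(C)Cn1cc(CO[C@H]2CC(=O)[C@@H]3OC[C@H]2O3)nn1` — 14300 nM
compound 3, `O=C1C[C@H](OCc2cc(-c3ccc([N+](=O)[O-])cc3)no2)[C@H]2CO[C@@H]1O2` — 11200 nM

All three were read in a functional assay on NCI-H1299 cells (Homo sapiens) for cytotoxicity, read by MTT assay, with a stated time of 48 h; a higher number here means a weaker inhibitor, a lower number a stronger inhibitor. Compound 3 gives 11200 nM there, the second highest of the three numbers; its nearest neighbour is compound 1 and its furthest is compound 2, and both gaps lie within the scatter, so the three compounds cannot be told apart on these data.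

Compound 4, `O=C1C[C@H](OCc2cc(-c3ccc(Cl)cc3)no2)[C@H]2CO[C@@H]1O2`, has not yet been measured. It differs from compound 3 by chloro in place of nitro on an aromatic carbon, placed on an aromatic carbon of a six-membered aromatic ring of carbon only, para to a large group.

Among the compounds with values here, the only measured step, a 1.3-fold higher number from compound 1 to compound 2 (0.12 log units; within the scatter), swaps a group on an aromatic nitrogen of a different ring and lay within the scatter; no measured step touches a substituent on the six-membered ring of carbon only. With nothing pointing either way, the expected step from compound 3 to compound 4 is a 1.0-fold lower number from compound 3 to compound 4 (0.01 log units; within the scatter), that is none beyond the scatter. Compound 4 is therefore estimated at 11000 nM, with a range from 5000 nM to 25000 nM.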

Compound 4, half-maximal inhibitory concentration: 9000 nM
For compound 4 the middle estimate is 1.2-fold (0.09 log units) above the measured one, and the stated range covers the measured number.
By their numbers in this assay, from the lowest: compounds 4, 1, 3 and 2 (each within the scatter of the next).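

The substituent on the six-membered aromatic ring of carbon only, para to a large group, now has its first measured change: in this assay, chloro in place of nitro gives a 1.2-fold lower number from compound 3 to compound 4 (0.09 log units; within the scatter) and stays within the scatter. Nitro, with its hydrogen-bond acceptors, and chloro, which has none, therefore cannot be told apart at this position, and this rests on a single pair of compounds. No measurement at hand bears on why the two groups read alike.

Going by these compounds, whether the same holds for an amine, a carboxylic acid or a longer chain at this position remains open. Also open, on these data alone, is whether any group here can move the number beyond the scatter, or whether the series stays as flat as these compounds.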